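Lengthening the Amine Chain on a Sulfonamide Core

The source may hold more compounds than are shown below. What is called first, only, known or untested is meant among the compounds shown, and "the series" means these compounds.

Of the compounds shown here, three sharing one core have been measured in an assay on VSM-A10 cells for antagonist activity at Endothelin-1 receptor (Rattus norvegicus); on this read-out lower numbers stand for stronger inhibition and higher numbers for weaker inhibition. Compound 2 `Cc1noc(NS(=O)(=O)c2cccc3c(NC(C)C)cccc23)c1C` gives 20 nM, the lowest number of the three. Compound 1 `Cc1noc(NS(=O)(=O)c2cccc3c(N4CCCCC4=O)cccc23)c1C` carries a 2-oxopiperidin-1-yl group on the aromatic carbon where compound 2 has isopropylamino; in this assay compound 1 gives 270 nM. Compound 3 `Cc1noc(NS(=O)(=O)c2cccc3c(Cl)cccc23)c1C`, with chloro at that carbon, gives 24000 nM. The steps are a 14-fold lower number from compound 1 to compound 2 (1.13 log units; beyond the scatter) and a 1200-fold higher number from compound 2 to compound 3 (3.08 log units; beyond the scatter), and between the two weaker compounds an 89-fold higher number from compound 1 to compound 3 (1.95 log units; beyond the scatter). Compound 2 is thus the strongest inhibitor among these three, since both steps leading away from it lie beyond the scatter.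

Compound 4 `Cc1noc(NS(=O)(=O)c2cccc3c(NCCCCCc4ccccc4)cccc23)c1C` keeps the nitrogen on the aromatic ring but changes what sits on it: 5-phenylpentyl in place of isopropyl on a nitrogen on an aromatic ring. The measured steps show that the group on that aromatic carbon matters greatly, yet none of them alters the chain on the nitrogen itself, so they set the stakes without pointing a direction. A far longer chain ending in an aromatic ring could be tolerated or could cost potency, and the data give no firm lean either way. Compound 4 is therefore expected to give about 50 nM, with an estimated range from 5 nM to 500 nM. The expected step is a 2.5-fold higher number from compound 2 to compound 4 (0.40 log units; beyond the scatter), which may well fall within the scatter.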

Compound 4, half-maximal inhibitory concentration: 3050 nM
The estimate for compound 4 lay 61-fold (1.79 log units) below the measured number; the measured number lies above the stated range.
By their numbers in this assay, from the lowest: compound 2; then compound 1; then compound 4; then compound 3.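

The nitrogen on the aromatic ring does not secure a low number by itself: with that nitrogen kept, 5-phenylpentyl in place of isopropyl gives a 150-fold higher number from compound 2 to compound 4 (2.18 log units; beyond the scatter) in this assay. The earlier steps shown here each replaced the whole group on the aromatic carbon, whereas this one changes only what sits on the nitrogen, and that change alone is large, taking the group from 3 heavy atoms and no ring to 11 heavy atoms with one six-membered aromatic ring. Even so, compound 4 at 3050 nM still gives a lower number than compound 3 at 24000 nM, so this long chain on the nitrogen does not bring the number as high as chloro on the aromatic carbon does.

Nothing available here bears on why this step is so large. The length of the chain and the phenyl ring at its end entered together, so the compounds shown leave open which of them accounts for the higher number, and how a plain pentyl chain, a benzyl group or a small ethyl group on that nitrogen would compare.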